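Trifluoromethyl to 1,1-difluoroethyl on the core of compound 2

A few compounds are considered here, and "the series" means these few. Any claim that something is new, unique, unknown or untested is made for them only; others in the source may bear on it.

Of the compounds shown here, two have numbers so far. In a physicochemical assay for solubility, using the shake flask method, in phosphate buffer, at pH 7 (a higher number here means a more soluble compound, a lower number a less soluble compound), compound 1 (`Cc1cc(C(=O)O)ccc1-c1ccc(Cl)c(-c2ccc(C(F)(F)F)cc2CN2C(=O)O[C@H](c3cc(C(F)(F)F)cc(C(F)(F)F)c3)[C@@H]2C)c1`) gives 43000 nM, and compound 2 (`COc1ccc(-c2ccc(C(=O)O)cc2C)cc1-c1cnc(C(F)(F)F)nc1CN1C(=O)O[C@H](c2cc(C(F)(F)F)cc(C(F)(F)F)c2)[C@@H]1C`) gives 6000 nM. Compound 2 therefore holds the lower of the two numbers, and its gap to compound 1 lies beyond the usual scatter. These two compounds differ in more than one place, so the gap does not measure any single change.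

Compound 3 (`COc1ccc(-c2ccc(C(=O)O)cc2C)cc1-c1cnc(C(C)(F)F)nc1CN1C(=O)O[C@H](c2cc(C(F)(F)F)cc(C(F)(F)F)c2)[C@@H]1C`) differs from compound 2 in one place (methyl in place of fluoro on a saturated chain carbon bound to an aromatic carbon and two fluorine atoms): methyl in place of fluoro on a saturated chain carbon bound to an aromatic carbon and two fluorine atoms. The same difference reads as trifluoromethyl to 1,1-difluoroethyl. For the measured compounds named here, no measured pair shows this change, and the data offer no direction for it. In this assay no step beyond the scatter is expected, and compound 2 at 6000 nM serves as the anchor. The estimated step of no change at the digits printed from compound 2 to compound 3 (within the scatter) is expected to be small. For compound 3 the expected solubility is 6000 nM, with an estimated range of 2000 nM to 18000 nM.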

Compound 3, solubility: 20000 nM
The estimate for compound 3 lay 3.3-fold (0.52 log units) below the measured number; the measured number lies above the stated range.
By their numbers in this assay, from the lowest: compound 2; then compound 3; then compound 1.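

In this assay the change from trifluoromethyl to 1,1-difluoroethyl gives a 3.3-fold higher number from compound 2 to compound 3 (0.52 log units; beyond the scatter) on the shared core of this pair. For the compounds shown here, this is the only step so far that isolates one change, and it shows that this place is not silent in this read-out: methyl in place of fluoro, with one heavy atom leaving and one entering and no change in ring, hydrogen-bond donor or acceptor counts or net charge, is enough to move the number beyond the scatter. Nothing available explains why the number moves with this change at this place.

Still open, on these data alone, is whether this single step reflects a trend at this place: a plain ethyl group, a longer chain such as 1,1-difluoropropyl, or an amine on the same carbon could carry the number further in the same direction, leave it where it stands, or reverse it. Also open, as far as these compounds go, is whether the same change would give a step of similar size and direction on a different core, such as that of compound 1, which carries a trifluoromethyl group in another setting.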